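The source may report more compounds than this note shows. Statements on the series, on what has been measured and on what is new or still open speak of the compounds shown alone.

Of the compounds shown here, two have so far been tested in a functional assay on MIA PaCa-2 cells (Homo sapiens) for inhibition, read by MTT assay, with a stated time of 7 days; on this read-out higher numbers stand for weaker inhibition and lower numbers for stronger inhibition. Compound 1 `CCOC(=O)[C@@H]1CCCN(S(=N)(=O)c2ccc(S(=O)(=O)N(CC)CC)cc2)C1` carries a sulfoximine on the ring nitrogen of the shared core, and in this assay compound 1 gives 12100 nM. Compound 2 `CCOC(=O)[C@@H]1CCCN(S(=O)(=O)c2ccc(S(=O)(=O)N3CCOCC3)cc2)C1` instead carries a sulfonyl there, and in this assay compound 2 gives 23500 nM. The gap between these two numbers lies within the usual scatter of repeated measurements, so the two compounds cannot be told apart on the evidence shown, and both inhibit the cells only weakly.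

Compound 3 `CCOC(=O)[C@@H]1CCCN(S(=O)(=O)c2ccc(S(=N)(=O)N(CC)CC)cc2)C1` keeps the sulfonyl of compound 2 but changes the group on the far side of the benzene ring: a group of 8 heavy atoms (4 carbon, 2 nitrogen, 1 oxygen, 1 sulfur; no ring) in place of a group of 9 heavy atoms (4 carbon, 1 nitrogen, 3 oxygen, 1 sulfur; one six-membered non-aromatic ring with 2 hetero atoms), on an aromatic carbon. For the measured compounds named here, no measured pair shows this exact change. The group that enters resembles the diethylsulfonamide of compound 1 with one oxygen exchanged for a nitrogen, and compound 1 and compound 2 sit within the scatter of each other, so the step from compound 2 to compound 3 is expected to be small, with no direction that clears the scatter, roughly a 1.6-fold lower number from compound 2 to compound 3 (0.19 log units; within the scatter). Compound 3 is therefore estimated at 15000 nM, within a range from 5000 nM to 45000 nM.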

Compound 3, half-maximal inhibitory concentration: 2600 nM
Beside the measured number, compound 3's estimate is 5.8-fold (0.76 log units) above it; measured number outside the range, below it.
By their numbers in this assay, from the lowest: compound 3; then compounds 1 and 2 (each within the scatter of the next).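

For the compounds shown here, the number at this place on the molecule is clearly not indifferent: with the sulfonyl on the ring nitrogen kept, swapping (morpholin-4-yl)sulfonyl on the aromatic carbon para to a large group for the open-chain group gives a 9.0-fold lower number from compound 2 to compound 3 (0.96 log units; beyond the scatter) in this assay and is the first step in this set that stands clear of the scatter. This single swap changes several things at once, since the six-membered ring is lost, hydrogen-bond donors go from 0 to 1 and hydrogen-bond acceptors go from 3 to 2, so the step alone cannot assign the gain to any one of these differences. No measurement is available here that bears on why the number falls.

Going by these compounds, it remains open whether the loss of the ring or the exchange of an oxygen for a nitrogen on the sulfur matters more, which a plain diethylsulfonamide at this place on the same core, or a morpholine ring carried on the new sulfur group, would help to separate. On these data alone, it is also open how far the step holds for other groups, such as a dimethylamine in place of the diethylamine, or a carboxylic acid in place of the ethyl ester.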